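A few compounds are considered here, and "the series" means these few. Any claim that something is new, unique, unknown or untested is made for them only; others in the source may bear on it.

Compound 1 `COc1cc(/C=C/C(=O)/C=C/c2cc(OC)c(OC)c(OC)c2)ccc1OCc1cn(CCOc2cc(=O)oc3ccccc23)nn1` and compound 2 `COc1cc(/C=C/C(=O)/C=C/c2ccco2)ccc1OCc1cn(CCOc2cc(=O)oc3ccccc23)nn1` share one core; compound 3 `COc1cc(/C=C/C(=O)/C=C/c2cc(OC)c(OC)c(OC)c2)ccc1OCc1cn(CCCCCOc2cc(=O)oc3ccccc23)nn1` and compound 4 `COc1cc(/C=C/C(=O)/C=C/c2ccco2)ccc1OCc1cn(CCCCCOc2cc(=O)oc3ccccc23)nn1` share another, and the difference between the two cores is not broken down here. In a functional assay on HCT-116 cells (Homo sapiens) for inhibition, read by sulforhodamine B assay, with a stated time of 48 h, tested at 50 uM (a lower number here means less inhibition of growth, a higher number more inhibition of growth at the concentration tested), compound 1 gives 89%, compound 2 gives 72% and compound 3 gives 53%, the lowest of the three. The change from compound 1 to compound 2 is furan-2-yl in place of 3,4,5-trimethoxyphenyl on a double-bonded chain carbon bound to a double-bonded chain carbon and gives the step of a number 17 percentage points lower from compound 1 to compound 2 (beyond the scatter). The same change, (furan-2-yl in place of 3,4,5-trimethoxyphenyl on a double-bonded chain carbon bound to a double-bonded chain carbon), is made from compound 3 to compound 4, which awaits measurement in this assay. Among the measured compounds shown here, a step of similar size is expected, a number 17 percentage points lower from compound 3 to compound 4 (beyond the scatter), because the one earlier instance gave a number 17 percentage points lower from compound 1 to compound 2 (beyond the scatter); with only one instance the footing is thin. Compound 4 is thus expected to give about 36%, within a range from 20% to 52%.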

Compound 4, percent growth inhibition at one concentration: 37%
The estimate for compound 4 lay 1 percentage points below the measured number; the measured number falls inside the stated range.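

In this assay, among the compounds shown here, furan-2-yl in place of 3,4,5-trimethoxyphenyl gives a number 16 percentage points lower from compound 3 to compound 4 (beyond the scatter), and the step carries over from one core to the other with its size intact: the same change on two cores in this assay, a number 17 percentage points lower (beyond the scatter) from compound 1 to compound 2 and a number 16 percentage points lower (beyond the scatter) from compound 3 to compound 4, 1 percentage points apart, within the scatter of two such steps This agreement rests on only two cores, so it supports carrying the change between the core of compound 1 and the core of compound 3 but sets no rule for any other core. It also gives no reason why the step keeps its size.

The compounds shown leave open whether the step would hold on a core with a longer chain. Also open, as far as these compounds go, is how a phenyl or pyridine ring in place of furan-2-yl would compare.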